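This account rests on a few compounds, and the source may have more. Where it says the series, first, only, none or still open, it means among the compounds named here.

Compound 1 `CN1CCCC(Cn2c(CN(C)C3CCCc4cccnc43)nc3ccccc32)C1`: 3000 nM
Compound 2 `CN1CCC[C@@H](Cn2c(CN(C)[C@@H]3CCCc4cccnc43)nc3ccccc32)C1`: 2800 nM
Compound 3 `CN1CCC[C@H](Cn2c(CN(C)[C@H]3CCCc4cccnc43)nc3ccccc32)C1`: 3600 nM

All three compounds were measured in an ADME assay on HOS cells (Homo sapiens) for cytotoxicity (a higher number here means that more compound is tolerated, a lower number that less compound is tolerated), and they cannot be told apart there. Compound 3 stands level with the other two, as the steps show: a 1.2-fold higher number from compound 1 to compound 3 (0.08 log units; within the scatter) and a 1.3-fold higher number from compound 2 to compound 3 (0.11 log units; within the scatter). The remaining step is a 1.1-fold lower number from compound 1 to compound 2 (0.03 log units; within the scatter). The two single-configuration compounds are related by the fact that compounds 2 and 3 differ only in the configuration as drawn, so the tolerated concentration in this assay shows no response to configuration across this set.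

The next compound, compound 4 `CN(Cc1nc2ccccc2n1C[C@H]1CCCN(Cc2cccnc2)C1)[C@H]1CCCc2cccnc21`, changes the structure itself. Compared with compound 3, it carries pyridin-3-yl in place of hydrogen on a saturated chain carbon bound to an amine nitrogen in a ring. In words, this is pyridin-3-yl in place of hydrogen on a saturated chain carbon bound to an amine nitrogen in a ring, so methyl becomes (pyridin-3-yl)methyl.

Among the compounds with values here, none of the measured steps alters atoms or bonds, so none tests this change directly. They offer only a flat baseline, and neither direction is favoured. The starting point is therefore compound 3 at 3600 nM, with a wide margin for the untested group. The expected change is small, and the estimate is a 1.0-fold lower number from compound 3 to compound 4 (0.01 log units; within the scatter). For compound 4 the expected value is 3500 nM, with an estimated range from 1000 nM to 12000 nM.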

Compound 4, half-maximal cytotoxic concentration: 2500 nM
Beside the measured number, compound 4's estimate is 1.4-fold (0.15 log units) above it; the range from low to high includes it.
By their numbers in this assay, from the lowest: compounds 4, 2, 1 and 3 (each within the scatter of the next).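

Within the data shown here, the earlier compounds differed only in configuration, so compound 4 is the first here to carry a change of atoms, and in this assay the step reads a 1.4-fold lower number from compound 3 to compound 4 (0.16 log units; within the scatter). Going from methyl to (pyridin-3-yl)methyl, with pyridin-3-yl on a saturated chain carbon bound to an amine nitrogen in a ring, therefore leaves compound 4 indistinguishable from compound 3 in this read-out, so the flat picture now extends from configuration to a first change in structure at this position. Among these compounds, what is known about these compounds offers no explanation for this result, since the only evidence at hand concerns configuration and not this group.

As far as these compounds go, it remains open whether the tolerated concentration would stay level with a different group at this place, such as a phenyl ring, a carboxylic acid or a longer chain carrying the pyridine. Also open, from the compounds shown here alone, is whether the mirror image of compound 4 would match it as closely as compounds 2 and 3 match each other.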